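Working notes: aryl replacement at the shared core, compound 4

The compounds below may be only part of what the source reports. "The series", "measured", "known", "first", "only" and "open" are said of these compounds alone.

Three measured compounds share one core. Compound 1 `CC(C(=O)NCc1ccc(C(F)(F)F)cc1N1CCC(C)(C)CC1)c1ccc(NS(C)(=O)=O)c(F)c1` carries a 4,4-dimethylpiperidin-1-yl group; in an assay on CHO cells for antagonist activity at transient receptor potential cation channel subfamily V member 1 (Homo sapiens), read by FLIPR (on this read-out lower numbers stand for stronger inhibition and higher numbers for weaker inhibition), compound 1 gives 1.3 nM. Compound 2 `CC(C(=O)NCc1ccc(C(F)(F)F)cc1-c1cccc(F)c1)c1ccc(NS(C)(=O)=O)c(F)c1` gives 1.9 nM, and compound 3 `CC(C(=O)NCc1ccc(C(F)(F)F)cc1-c1cccc(Cl)c1)c1ccc(NS(C)(=O)=O)c(F)c1` gives 1 nM. Compound 3 has the lowest of the three numbers, but its separation from the others is small: a 1.3-fold lower number from compound 1 to compound 3 (0.11 log units; within the scatter) and a 1.9-fold lower number from compound 2 to compound 3 (0.28 log units; within the scatter), so no order among the three is established.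

Compound 4 `COc1cc(OC)cc(-c2cc(C(F)(F)F)ccc2CNC(=O)C(C)c2ccc(NS(C)(=O)=O)c(F)c2)c1` differs from compound 3 by one change: 3,5-dimethoxyphenyl in place of 3-chlorophenyl on an aromatic carbon. Among the measured compounds shown here, the steps that bear on this are a 1.5-fold higher number from compound 1 to compound 2 (0.16 log units; within the scatter) and a 1.3-fold lower number from compound 1 to compound 3 (0.11 log units; within the scatter), in which an aryl group took the place of the 4,4-dimethylpiperidin-1-yl group, and a 1.9-fold lower number from compound 2 to compound 3 (0.28 log units; within the scatter), in which one halogen replaced another on that aryl group. All three stayed within the scatter. For the measured compounds named here, no measured step introduces a methoxy group or a 3,5-disubstituted aryl group, so the effect of the two methoxy groups in compound 4 is not covered by the data.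

Given that every aryl variation seen so far left this assay unchanged within the scatter, compound 4 is expected to show no step beyond the scatter, a 1.6-fold higher number from compound 3 to compound 4 (0.20 log units; within the scatter). The estimate for compound 4 is 1.6 nM, with a range from 0.5 nM to 5 nM.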

Compound 4, inhibition constant: 5.8 nM
Compound 4: middle estimate off by 3.6-fold (0.56 log units), on the low side; the whole stated range lies below it.
By their numbers in this assay, from the lowest: compounds 3, 1 and 2 (each within the scatter of the next); then compound 4.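

In this assay, this position, ortho to a large group and meta to a trifluoromethyl group, does respond to the aryl group it carries: 3,5-dimethoxyphenyl gives a step beyond the scatter against 3-chlorophenyl (a 5.8-fold higher number from compound 3 to compound 4 (0.76 log units; beyond the scatter)) and against 3-fluorophenyl (a 3.1-fold higher number from compound 2 to compound 4 (0.48 log units; beyond the scatter)), whereas the exchange of one halogen for the other on the aryl group stayed within the scatter. The same holds against the non-aromatic 4,4-dimethylpiperidin-1-yl group (a 4.5-fold higher number from compound 1 to compound 4 (0.65 log units; beyond the scatter)), so the earlier agreement among compound 1, compound 2 and compound 3 does not extend to every group at this position, although all three new steps are modest. Nothing available explains why the 3,5-dimethoxyphenyl group gives the higher number.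

Still open, as far as these compounds go, is whether the shift needs both methoxy groups or follows from one alone, which a 3-methoxyphenyl group would separate, and whether a 3,5-dichlorophenyl group would read like the 3,5-dimethoxyphenyl group or like the 3-chlorophenyl group. Also open, from the compounds shown here alone, is how an aryl group bearing an amine or a carboxylic acid would read at this position in this assay.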